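Chloro to Methoxy on a Longer Side Chain

This account rests on a few compounds, and the source may have more. Where it says the series, first, only, none or still open, it means among the compounds named here.

Compound 1 `CCCCC(CCO)n1cnc2c(Cl)ncnc21` and compound 2 `CCCCC(CCO)n1cnc2c(OC)ncnc21` share a core and differ by methoxy in place of chloro on an aromatic carbon. In a functional assay on SW480 cells (Homo sapiens) for antiproliferative activity, read by MTT assay, with a stated time of 48 h (a higher number here means a weaker inhibitor, a lower number a stronger inhibitor), compound 1 gives only a limit of the assay, > 50000 nM. Compound 2 likewise gives only a limit in this assay, > 50000 nM. The step between them is a step that the two limits leave unreadable from compound 1 to compound 2 because of the limit of > 50000 nM in this assay, at which 2 of the 3 values shown sit. Compound 3 `CCCCCCC(CCO)n1cnc2c(Cl)ncnc21` differs from compound 1 by ethyl in place of hydrogen on a saturated chain carbon, five bonds along the chain from an aromatic nitrogen, and in this assay compound 3 gives 16700 nM, which is an at least 2.9-fold lower number from compound 1 to compound 3 (0.47 log units; beyond the scatter). Compound 4 `CCCCCCC(CCO)n1cnc2c(OC)ncnc21` differs from compound 3 by the same change, (methoxy in place of chloro on an aromatic carbon). Since the earlier occurrence of this change yields no readable size, the step from compound 3 to compound 4 is expected to be a 1.8-fold higher number from compound 3 to compound 4 (0.25 log units; within the scatter). Compound 4 is estimated at 30000 nM, with a real chance that only a limit is reported.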

Compound 4, half-maximal inhibitory concentration: > 50000 nM
Compound 4 gave a limit, no number; the forecaster's own chance of this, stated with the estimate: 40%; middle value at least 1.6-fold (0.22 log units) from the limit.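

On the longer chain, methoxy in place of chloro gives in this assay an at least 2.9-fold higher number from compound 3 to compound 4 (0.47 log units; beyond the scatter), and this size is only a lower bound, since compound 4 gives a limit and no number. The same change on the shorter chain and the ethyl step between the two methoxy compounds cannot be read, because both members of each pair sit at the limit: the limit of > 50000 nM in this assay, at which 3 of the 4 values shown sit. The series thus shows the change raising the number on one core only, and it does not show whether the step carries over to the shorter chain or how large it truly is.

Still open, going by these compounds, is how an amine in place of chloro would read on either core. On these data alone, it is also open whether a longer chain would lower the number further.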